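Shifting the Methoxy Group on an Aryl Substituent

The source may report more compounds than this note shows. Statements on the series, on what has been measured and on what is new or still open speak of the compounds shown alone.

Compound 2 `COc1ccc(-n2nncc2CN2C(=O)C3(C(C#N)=C(N)Oc4c3c3nc5ccccc5nc3c3ccccc43)c3ccccc32)cc1` is the starting point here. In a functional assay on HCT-116 cells (Homo sapiens) for antiproliferative activity, read by MTT assay, with a stated time of 48 h (a higher number here means a weaker inhibitor, a lower number a stronger inhibitor), compound 2 gives > 50000 nM, which is a limit of the assay rather than a measured number. Its closest relative is compound 1 `Cc1cccc(-n2nncc2CN2C(=O)C3(C(C#N)=C(N)Oc4c3c3nc5ccccc5nc3c3ccccc43)c3ccccc32)c1`, which carries a 3-methylphenyl group where compound 2 carries 4-methoxyphenyl. In this assay compound 1 gives > 50000 nM, again a limit. The step that the two limits leave unreadable from compound 1 to compound 2 therefore cannot be read, and the limit of > 50000 nM in this assay, at which 2 of the 2 values shown sit, sums up how little the two numbers say. Compound 3 `COc1ccccc1-n1nncc1CN1C(=O)C2(C(C#N)=C(N)Oc3c2c2nc4ccccc4nc2c2ccccc32)c2ccccc21` differs from compound 2 in one place: 2-methoxyphenyl in place of 4-methoxyphenyl on an aromatic nitrogen. For the measured compounds named here, no measured step shows what moving the methoxy group does, and the only related change, from 3-methylphenyl to 4-methoxyphenyl, left both compounds at the limit. With nothing to suggest a gain, compound 3 is expected to remain at the limit as well, an estimated 60000 nM with a range from 20000 nM to 200000 nM. The step that this estimate implies, a step that the limit leaves unreadable from compound 2 to compound 3, is expected to be no real change.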

Compound 3, half-maximal inhibitory concentration: > 50000 nM
Compound 3: no number, only a limit; the forecaster's own chance of this, stated with the estimate: 85%; the middle value is on the limit's open side.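

In this assay compound 3 gives > 50000 nM, again a limit and not a number. No step between compound 1, compound 2 and compound 3 can be read, and one fact sums up why: the limit of > 50000 nM in this assay, at which 3 of the 3 values shown sit. The compounds shown leave open whether any aryl group at this place on the shared core gives a readable number in this assay.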